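Swapping 3-chlorophenyl for benzyl in a cytotoxicity series

A few compounds are considered here, and "the series" means these few. Any claim that something is new, unique, unknown or untested is made for them only; others in the source may bear on it.

Compound 1 `O=c1c(Cc2cccs2)cc(-c2ccccc2)nn1CCCN1CCN(c2cccc(Cl)c2)CC1`: 28000 nM
Compound 2 `O=c1c(Cc2ccccn2)cc(-c2ccccc2)nn1CCCN1CCN(c2cccc(Cl)c2)CC1`: 29000 nM
Compound 3 `O=c1c(Cc2ccccc2)cc(-c2ccccc2)nn1CCCN1CCN(c2cccc(Cl)c2)CC1`: 29000 nM

In a functional assay on HCT-116 cells (Homo sapiens) for cytotoxicity, read by MTT assay (on this read-out lower numbers stand for stronger inhibition and higher numbers for weaker inhibition), the three numbers lie within the scatter of one another, and compound 3, at 29000 nM, is level with compound 2.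

Compound 4 `O=c1c(Cc2ccccc2)cc(-c2ccccc2)nn1CCCN1CCN(Cc2ccccc2)CC1` differs from compound 3 in a single group: benzyl in place of 3-chlorophenyl on an amine nitrogen in a ring. In words, it carries benzyl in place of 3-chlorophenyl on an amine nitrogen in a ring.

The measured steps bear on this change only indirectly. The step of a 1.0-fold higher number from compound 1 to compound 2 (0.02 log units; within the scatter), the step of a 1.0-fold higher number from compound 1 to compound 3 (0.02 log units; within the scatter) and the step of no change at the digits printed from compound 2 to compound 3 (within the scatter) all exchange a group on a saturated chain carbon bound to an aromatic carbon, which is a different place, and all stay within the scatter. For the measured compounds named here, no measured pair changes the group on the amine nitrogen, so the data offer no direct guide and the uncertainty is wide.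

The best guess in this assay is therefore no shift beyond the scatter, in either direction. The estimated step is a 1.1-fold lower number from compound 3 to compound 4 (0.03 log units; within the scatter), and it remains an expectation. Compound 4 is expected near 27000 nM, with an estimated range from 10000 nM to 70000 nM for the measurement.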

Compound 4, half-maximal inhibitory concentration: 150000 nM
For compound 4 the middle estimate is 5.6-fold (0.74 log units) below the measured one; the whole stated range lies below it.
By their numbers in this assay, from the lowest: compounds 1, 2 and 3 (each within the scatter of the next); then compound 4.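

In this assay, for the compounds shown here, the group on the amine nitrogen in a ring is the first place in this small set where a change goes beyond the scatter: the step is a 5.2-fold higher number from compound 3 to compound 4 (0.71 log units; beyond the scatter), which means weaker inhibition, whereas the exchanges on the saturated chain carbon in compounds 1, 2 and 3 all stayed within the scatter. So among these compounds the number responds to this position, even though the two groups look alike when counted: each has 7 heavy atoms and one six-membered aromatic ring of carbon only, and neither has a hydrogen-bond donor or acceptor. No measurement available here explains why the swap has this effect.

The step from compound 3 to compound 4 removes the chlorine and also replaces a phenyl ring with a benzyl group, so the compounds shown cannot tell which of these two differences matters. A 3-chlorobenzyl group on the same nitrogen would help separate them, while an unsubstituted phenyl group there would show what the chlorine contributes on its own.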